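Methoxy in place of hydrogen: compound 4 against compound 1

A few compounds are considered here, and "the series" means these few. Any claim that something is new, unique, unknown or untested is made for them only; others in the source may bear on it.

Measured compounds in a functional assay on MDA-MB-231 cells (Homo sapiens) for cytotoxicity, read by MTT assay; on this read-out higher numbers stand for weaker inhibition and lower numbers for stronger inhibition:
- compound 1, `c1ccc(-c2nnc(-c3c[nH]c4ccccc34)o2)cc1`. In this assay compound 1 gives > 1000000 nM, which is a limit of the assay and not a number.
- compound 2, `c1ccc(Cc2nnc(-c3c[nH]c4ccccc34)o2)cc1`. In this assay compound 2 gives > 1000000 nM, again a limit.
- compound 3, `c1cncc(-c2nnc(-c3c[nH]c4ccccc34)o2)c1`. In this assay compound 3 gives > 1000000 nM, again a limit.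

Compound 1 therefore stands at the limit of > 1000000 nM in this assay, at which 3 of the 3 values shown sit; none of the three compounds has a numerical value. For the measured compounds named here, the steps a step that the two limits leave unreadable from compound 1 to compound 2, a step that the two limits leave unreadable from compound 1 to compound 3 and a step that the two limits leave unreadable from compound 2 to compound 3 are all unreadable in size, so no measured step tells how a change on the phenyl of compound 1 moves this assay.

Compound 4, `COc1ccc(-c2nnc(-c3c[nH]c4ccccc34)o2)cc1`, differs from compound 1 by methoxy in place of hydrogen on an aromatic carbon. Going by the values given here, no measured step bears on a methoxy group; the phenyl changes that were measured gave only limits. Compound 4 is expected to sit at the limit as well, with an estimate of 1000000 nM, between 300000 nM and 3000000 nM. The expected step is therefore a number no higher from compound 1 to compound 4 (the limit leaves the size open), most likely again unreadable.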

Compound 4, half-maximal inhibitory concentration: > 1000000 nM
Compound 4 ended at the assay's limit; the forecaster's own chance of this, stated with the estimate: 80%; the middle value lies on the limit itself.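

No size can be read for the step between compound 1 and compound 4, which both give a limit of the assay and not a number: the limit of > 1000000 nM in this assay, at which 4 of the 4 values shown sit.

The compounds shown leave open how far methoxy, or any other change on the phenyl, moves this assay.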